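Amino in place of the ester: compound 4 expected

A few compounds are considered here, and "the series" means these few. Any claim that something is new, unique, unknown or untested is made for them only; others in the source may bear on it.

Compound 3 `CC(C)(C)C(=O)OCc1ccc2oc(=O)c(C(=O)Oc3cccc(Br)c3)cc2c1` stands second highest of the three numbers: in a functional assay on HT-1080 cells (Homo sapiens), read by transwell migration, with a stated time of 24 h, tested at 0.1 uM (a lower number here means a stronger effect, a higher number a weaker effect of the compound at the concentration tested), compound 3 gives 65.2%, compound 2 `CCCC(=O)OCc1ccc2oc(=O)c(C(=O)Oc3cccc(Br)c3)cc2c1` gives 88.6% and compound 1 `CC(=O)OCc1ccc2oc(=O)c(C(=O)Oc3cccc(Br)c3)cc2c1` gives 39.5%. The steps reaching compound 3, a number 25.7 percentage points higher from compound 1 to compound 3 (beyond the scatter) and a number 23.4 percentage points lower from compound 2 to compound 3 (beyond the scatter), were modest, while a number 49.1 percentage points higher from compound 1 to compound 2 (beyond the scatter) was large; all three only swap the group on the carbonyl carbon. Compound 4 `NCc1ccc2oc(=O)c(C(=O)Oc3cccc(Br)c3)cc2c1` changes something else: amino in place of ((tert-butyl)carbonyl)oxy on a saturated chain carbon bound to an aromatic carbon. For the measured compounds named here, no measured step removes the ((tert-butyl)carbonyl)oxy group or brings in amino, so the measured steps give no direction, only a sign that this position moves the read-out. Compound 4 is therefore estimated near the middle of the observed spread, at 62% with a range of 28% to 95%. The implied step, a number 3.2 percentage points lower from compound 3 to compound 4 (within the scatter), is an expectation carried by little evidence.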

Compound 4, a percentage reported as activity, at one concentration (the size of the read-out at that concentration, not a potency): 88.3%
Estimate against measurement, compound 4: 26.3 percentage points below; low and high end bracket the measured number.
By their numbers in this assay, from the lowest: compound 1; then compound 3; then compounds 4 and 2 (each within the scatter of the next).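

Amino on a saturated chain carbon bound to an aromatic carbon removes the ester from this position entirely, and in this assay this gives a number 23.1 percentage points higher from compound 3 to compound 4 (beyond the scatter) and a number 48.8 percentage points higher from compound 1 to compound 4 (beyond the scatter) while the comparison with the butyrate-type group gives a number 0.3 percentage points lower from compound 2 to compound 4 (within the scatter) in this series. An ester is thus not required for the high end of the read-out, shared by compound 2 and compound 4, and amino does not keep the stronger effect of acetoxy in compound 1. No available evidence accounts for these differences.

From the compounds shown here alone, whether the effect of acetoxy comes from the ester itself stays open. A hydroxyl, an acetamide or a dimethylamino group on this carbon would help separate the loss of acetoxy from the entry of amino.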